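Methoxyphenyl variation on the shared core: outlook for compound 3

The source may report more compounds than this note shows. Statements on the series, on what has been measured and on what is new or still open speak of the compounds shown alone.

Measured so far in a functional assay on MCF7 cells (Homo sapiens) for antiproliferative activity; on this read-out higher numbers stand for weaker inhibition and lower numbers for stronger inhibition:
compound 1, `COc1ccc(/C=C/C(=O)c2ccc(OCCCN3C(=O)/C=C/C(C)(C)C/C=C(\C)CC/C=C/3C)cc2)cc1`, gives 3.17 ug/mL.
compound 2, `COc1ccccc1/C=C/C(=O)c1ccc(OCCCN2C(=O)/C=C/C(C)(C)C/C=C(\C)CC/C=C/2C)cc1`, gives 1.56 ug/mL.

Within the data shown here, compound 2 holds the lowest number of the two measured; the only measured step is a 2.0-fold lower number from compound 1 to compound 2 (0.31 log units; beyond the scatter), a modest change that is nonetheless beyond the scatter.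

Compound 3, `COc1cc(/C=C/C(=O)c2ccc(OCCCN3C(=O)/C=C/C(C)(C)C/C=C(\C)CC/C=C/3C)cc2)cc(OC)c1OC`, differs from compound 2 in that (3,4,5-trimethoxyphenyl in place of 2-methoxyphenyl on a double-bonded chain carbon bound to a double-bonded chain carbon). Among the measured compounds shown here, the single step that bears on this, a 2.0-fold lower number from compound 1 to compound 2 (0.31 log units; beyond the scatter), concerned only the arrangement of one methoxy on the same ring and gave a modest lowering; no measured pair shows what two further methoxy groups do. The direction is therefore open, and the step is expected to be no larger than the scatter, as a 1.0-fold lower number from compound 2 to compound 3 (0.02 log units; within the scatter), with a wide band around it. For compound 3 the expected value in this assay is 1.5 ug/mL, estimated to lie between 0.4 ug/mL and 5.5 ug/mL.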

Compound 3, half-maximal inhibitory concentration: 0.58 ug/mL
Compound 3: the middle estimate sits 2.6-fold (0.41 log units) above what was measured, within the range that was stated.
By their numbers in this assay, from the lowest: compound 3; then compound 2; then compound 1.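

In this assay the 3,4,5-trimethoxyphenyl group gives a 2.7-fold lower number from compound 2 to compound 3 (0.43 log units; beyond the scatter) and also a 5.5-fold lower number from compound 1 to compound 3 (0.74 log units; beyond the scatter) on the same shared core, so compound 3 holds the lowest number of the three, with both steps beyond the scatter. The earlier pair showed only a change between two rings bearing one methoxy each; this result shows that a ring bearing three methoxy groups is accepted on a double-bonded chain carbon bound to a double-bonded chain carbon and gives a lower number than either single-methoxy ring. No measurement at hand offers an explanation for these lower numbers.

The compounds shown cannot separate the number of methoxy groups from their arrangement, as both differ together in compound 3. Going by these compounds, it remains open whether a hydroxy group, an amine or a longer alkoxy chain on this ring would keep, lower or raise the number.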